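Fluoro on the Fused Ring of Compound 3

A few compounds are considered here, and "the series" means these few. Any claim that something is new, unique, unknown or untested is made for them only; others in the source may bear on it.

Three compounds share one core, a cyclic imide joined to a thiazole that carries a para-substituted phenyl ring. Compound 1 `O=C1c2ccccc2C(=O)N1c1nc(-c2ccc(Cl)cc2)cs1` bears a chloro group there, compound 2 `COc1ccc(-c2csc(N3C(=O)c4ccccc4C3=O)n2)cc1` a methoxy group, and compound 3 `O=C1c2ccccc2C(=O)N1c1nc(-c2ccc([N+](=O)[O-])cc2)cs1` a nitro group. In a functional assay on PC-3 cells (Homo sapiens) for antiproliferative activity, read by MTT assay, with a stated time of 48 h (a higher number here means a weaker inhibitor, a lower number a stronger inhibitor), compound 1 gives 44900 nM, compound 2 gives 42900 nM and compound 3 gives 41800 nM. The steps of a 1.0-fold lower number from compound 1 to compound 2 (0.02 log units; within the scatter), a 1.1-fold lower number from compound 1 to compound 3 (0.03 log units; within the scatter) and a 1.0-fold lower number from compound 2 to compound 3 (0.01 log units; within the scatter) all lie within the scatter, so the three numbers cannot be told apart, and compound 3 sits among them rather than apart from them.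

Compound 4 `O=C1c2ccc(F)cc2C(=O)N1c1nc(-c2ccc([N+](=O)[O-])cc2)cs1` keeps the nitro group of compound 3 and differs only in the other ring: fluoro in place of hydrogen on an aromatic carbon, on the six-membered aromatic ring of carbon only that is part of the fused system of two rings. Among the compounds with values here, no measured step touches that ring; the three known steps all change the para group on the phenyl ring and none of them moved the number beyond the scatter. Nothing here supports an expected shift in either direction, so in this assay the expected step is a 1.0-fold lower number from compound 3 to compound 4 (0.02 log units; within the scatter). Compound 4 is therefore estimated at 40000 nM, within a range from 15000 nM to 110000 nM.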

Compound 4, half-maximal inhibitory concentration: 39900 nM
The estimate for compound 4 lay 1.0-fold (0.00 log units) above the measured number, within the range that was stated.
By their numbers in this assay, from the lowest: compounds 4, 3, 2 and 1 (each within the scatter of the next).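

Until now every measured step had changed the group on the phenyl ring, so nothing was known about the fused system of two rings. Within the data shown here, the first step to touch that system, fluoro in place of hydrogen on one of its aromatic carbons, gives a 1.0-fold lower number from compound 3 to compound 4 (0.02 log units; within the scatter) in this assay, so this single replacement leaves compound 4 indistinguishable from compound 3, at least while the nitro group stays on the phenyl ring. No measurement is at hand that would explain this result, so it stands as an observation only.

Fluoro adds just one heavy atom, and whether an amine, a carboxylic acid or a longer chain on this same carbon would also leave the number within the scatter remains open. Also open, on these data alone, is whether fluoro at this place gives the same result alongside the chloro group of compound 1 or the methoxy group of compound 2, and whether the other carbons of this ring tolerate the same replacement.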